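The compounds below may be only part of what the source reports. "The series", "measured", "known", "first", "only" and "open" are said of these compounds alone.

Of the compounds shown here, three with a shared core have been tested in a functional assay on Ehrlich cells (Mus musculus) for cytotoxicity, tested at 100 ug/mL; on this read-out lower numbers stand for a weaker effect and higher numbers for a stronger effect at the one concentration tested. Compound 1 `COc1cc(N2C(N)=C(C#N)C(c3ccc([N+](=O)[O-])cc3)C3=C2CC(C)(C)CC3=O)cc(OC)c1OC` gives 80%, which places it second highest of the three. Compound 2 `COc1ccccc1C1C(C#N)=C(N)N(c2cc(OC)c(OC)c(OC)c2)C2=C1C(=O)CC(C)(C)C2` gives 100%, and the step of a number 20 percentage points higher from compound 1 to compound 2 (beyond the scatter) is the nearer of the two around compound 1. Compound 3 `COc1cc(N2C(N)=C(C#N)C(c3ccccc3)C3=C2CC(C)(C)CC3=O)cc(OC)c1OC` gives 10%, and the step of a number 70 percentage points lower from compound 1 to compound 3 (beyond the scatter) is by far the larger one. The remaining step, a number 90 percentage points lower from compound 2 to compound 3 (beyond the scatter), shows the same pattern, in that both compounds carrying a substituted phenyl group on the saturated ring carbon stand well above compound 3 with its bare phenyl.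

Compound 4 `COc1cc(N2C(N)=C(C#N)C(c3ccc(O)cc3)C3=C2CC(C)(C)CC3=O)cc(OC)c1OC` has not yet been tested. Its difference from compound 1 is hydroxy in place of nitro on an aromatic carbon. Among the measured compounds shown here, the steps that bear on this change are those from compound 1 to compound 3 and from compound 2 to compound 3, which both show that losing the group on that phenyl ring costs a great deal in this assay. Here the group is exchanged rather than removed, so a smaller drop than in those steps is expected, though with wide uncertainty. From compound 1 the expected change is a number 25 percentage points lower from compound 1 to compound 4 (beyond the scatter). Compound 4 is therefore estimated at 55%, in a range from 20% to 90%.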

Compound 4, a percentage reported as activity, at one concentration (the size of the read-out at that concentration, not a potency): 100%
Compound 4: the middle estimate sits 45 percentage points below what was measured; measured number outside the range, above it.
By their numbers in this assay, from the lowest: compound 3; then compound 1; then compounds 2 and 4 (each within the scatter of the next).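

In this assay, the exchange of nitro for hydroxy on this aromatic carbon gives a number 20 percentage points higher from compound 1 to compound 4 (beyond the scatter) and so costs nothing, which shows that the number of compound 1 does not depend on the nitro group itself. Hydroxy also gives a number 90 percentage points higher from compound 3 to compound 4 (beyond the scatter) when it takes the place of hydrogen, so two quite different groups at this carbon, para to a large group, now stand well above the bare phenyl of compound 3. The 4-hydroxyphenyl and 2-methoxyphenyl groups cannot be told apart here, with no change at the digits printed from compound 2 to compound 4 (within the scatter) between them.

As far as these compounds go, whether an amine, a carboxylic acid or a simple methyl on the same carbon would also hold the number up stays open, and the read-out tells only of a stronger or weaker effect at the one concentration tested. Nothing measured here explains why these substituents lift the number over the bare phenyl.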